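The source may report more compounds than this note shows. Statements on the series, on what has been measured and on what is new or still open speak of the compounds shown alone.

The three compounds measured so far in a functional assay on T47D cells (Homo sapiens) for activation (a lower number here means that less compound is needed, a higher number that more compound is needed for the effect), are:

compound 1, `COc1ccc2c(c1)OC(N)=C(C#N)C2c1ccccc1`: 360000000 nM
compound 2, `COc1ccc2c(c1)OC(N)=C(C#N)C2c1cccc(Cl)c1`: 80000000 nM
compound 3, `COc1ccc2c(c1)OC(N)=C(C#N)C2c1cccc([N+](=O)[O-])c1`: 88900000 nM

Compound 2 and compound 3 cannot be told apart, the gap being a 1.1-fold higher number from compound 2 to compound 3 (0.05 log units; within the scatter). Both stand well away from compound 1: the step of a 4.5-fold lower number from compound 1 to compound 2 (0.65 log units; beyond the scatter) and the step of a 4.0-fold lower number from compound 1 to compound 3 (0.61 log units; beyond the scatter) are modest but beyond the scatter. So compound 2 sits where the two substituted compounds cluster, apart from the unsubstituted parent.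

Compound 4, `CCNc1ccc2c(c1)OC(N)=C(C#N)C2c1cccc(Cl)c1`, keeps the chloro of compound 2 and alters the fused ring instead: ethylamino in place of methoxy on an aromatic carbon. Among the compounds with values here, no measured step touches this position; the three steps seen all concern the pendant ring carrying the chloro or nitro group, and even those were modest at most. Nothing in the data therefore indicates a direction for this change, and the expectation rests on compound 2 alone. The expected step for compound 4 is no change at the digits printed from compound 2 to compound 4 (within the scatter), with a wide band in either direction. Compound 4 is accordingly estimated at 80000000 nM, within a range from 15000000 nM to 400000000 nM.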

Compound 4, half-maximal effective concentration: 120000000 nM
Beside the measured number, compound 4's estimate is 1.5-fold (0.18 log units) below it, and the stated range covers the measured number.
By their numbers in this assay, from the lowest: compounds 2, 3 and 4 (each within the scatter of the next); then compound 1.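

The first change shown on the fused ring leaves the number in this assay essentially where it was, with a 1.5-fold higher number from compound 2 to compound 4 (0.18 log units; within the scatter). At this aromatic carbon, therefore, ethylamino, with 3 heavy atoms and 1 hydrogen-bond donor, can stand in place of methoxy, with 2 heavy atoms and 0 hydrogen-bond donors, without a change that can be told from the scatter, at least while the chloro group stays on the pendant ring. No supporting evidence bears on why this exchange makes so little difference.

On these data alone, since this rests on a single pair, it remains open whether the same exchange would be equally quiet with the nitro group of compound 3 or the unsubstituted pendant ring of compound 1. As far as these compounds go, it also remains open how this position would respond to a free amine, a hydroxyl, a dimethylamino group or a longer alkoxy chain, and whether anything placed here could shift the number by more than the substituents on the pendant ring have done.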